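The compounds below may be only part of what the source reports. "The series", "measured", "known", "first", "only" and "open" are said of these compounds alone.

Series notes. Compound 1 `CC(C)(C)N(NC(=O)c1ccccc1Br)C(=O)c1ccccc1Cl` and compound 2 `CC(C)(C)N(NC(=O)c1ccccc1I)C(=O)c1ccccc1Cl` share a core and differ in iodo in place of bromo on an aromatic carbon; in an assay on cells for agonist activity at ecdysone receptor (Bombyx mori), read by a luciferase reporter, with a stated time of 24 h (on this read-out higher numbers stand for an effect only at larger amounts of compound and lower numbers for an effect already at smaller amounts), compound 1 gives 316 nM and compound 2 gives 1290 nM, a step of a 4.1-fold higher number from compound 1 to compound 2 (0.61 log units; beyond the scatter). Compound 3 `CC(C)(C)N(NC(=O)c1ccc(Br)cc1)C(=O)c1ccccc1Cl` differs from compound 1 in 4-bromophenyl in place of 2-bromophenyl on a carbonyl carbon, and in this assay compound 3 gives 33.9 nM, the step being a 9.3-fold lower number from compound 1 to compound 3 (0.97 log units; beyond the scatter). Compound 4 `CC(C)(C)N(NC(=O)c1ccc(I)cc1)C(=O)c1ccccc1Cl` is not yet measured; it differs from compound 3 in iodo in place of bromo on an aromatic carbon, the same kind of change as between compound 1 and compound 2, though there the place is ortho to a large group and here it is para to a large group. Because the earlier step was a 4.1-fold higher number from compound 1 to compound 2 (0.61 log units; beyond the scatter), a step of similar size, a 2.9-fold higher number from compound 3 to compound 4 (0.47 log units; beyond the scatter), is expected for compound 4. Compound 4 is therefore estimated at 100 nM, with a range from 35 nM to 300 nM.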

Compound 4, half-maximal effective concentration: 7.59 nM
Estimate against measurement, compound 4: 13-fold (1.12 log units) above; the whole stated range lies above it.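

In this assay the exchange of bromo for iodo does not carry from one core to the other with a fixed direction or size: the same change on two cores in this assay, a 4.1-fold higher number (0.61 log units; beyond the scatter) from compound 1 to compound 2 and a 4.5-fold lower number (0.65 log units; beyond the scatter) from compound 3 to compound 4, 18-fold (1.26 log units) apart, beyond the scatter of two such steps Para to a large group the change gives a 4.5-fold lower number from compound 3 to compound 4 (0.65 log units; beyond the scatter), while 4-iodophenyl in place of the ortho-substituted rings gives a 170-fold lower number from compound 2 to compound 4 (2.23 log units; beyond the scatter) and a 42-fold lower number from compound 1 to compound 4 (1.62 log units; beyond the scatter). These two pairs show that the outcome of this change depends on the core carrying it, but they do not explain the reversal or give a rule for any further core.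

Open, from the compounds shown here alone, is how chloro, fluoro or methoxy would read in place of iodo, para to a large group. Also open, going by these compounds, is what a change to the chlorine-bearing ring, constant across all four compounds, would do.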